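Removing a Chloro Group Across Two Related Cores

The source may report more compounds than this note shows. Statements on the series, on what has been measured and on what is new or still open speak of the compounds shown alone.

Compound 1 `O=C(COc1ccc(C(=O)/C=C/c2ccc(Cl)cc2Cl)cc1)N[C@H]1CCOC1=O` and compound 2 `O=C(COc1ccc(C(=O)/C=C/c2ccccc2Cl)cc1)N[C@H]1CCOC1=O` share one core, while compound 3 `O=C(CNc1cccc(Cl)c1)N[C@H]1CCOC1=O` and compound 4 `O=C(CNc1ccccc1)N[C@H]1CCOC1=O` share another; how the two cores differ is not broken down here. In a functional assay on MCF7 cells (Homo sapiens) for antiproliferative activity, read by MTT assay, with a stated time of 72 h (on this read-out lower numbers stand for stronger inhibition and higher numbers for weaker inhibition), compound 1 gives 34400 nM. In this assay compound 2 gives 17400 nM. The change between them is hydrogen in place of chloro on an aromatic carbon, and it produced a 2.0-fold lower number from compound 1 to compound 2 (0.30 log units; within the scatter). For compound 3 the assay reports only a limit, > 64000 nM, which is the limit of > 64000 nM in this assay, at which 1 of the 3 values shown sits. Compound 4 differs from compound 3 by the same kind of change, (hydrogen in place of chloro on an aromatic carbon); here the place is meta to a large group, whereas in compound 1 the place was meta to a chloro group and para to a large group. The measured step of a 2.0-fold lower number from compound 1 to compound 2 (0.30 log units; within the scatter) stayed within the scatter, so little movement is expected for compound 4 as well: the expected step is a number no higher from compound 3 to compound 4 (the limit leaves the size open). Compound 4 is therefore estimated in this assay at 64000 nM, with a likely range from 30000 nM to 150000 nM, and it may well again be reported only as a limit.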

Compound 4, half-maximal inhibitory concentration: > 64000 nM
Compound 4: no number, only a limit; the forecaster's own chance of this, stated with the estimate: 65%; the middle value sits exactly at the limit.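

In this assay, within the data shown here, compound 4 gives only a limit, > 64000 nM, and compound 3 is also reported only as a limit, so no step between compound 3 and compound 4 can be read. The same limit recurs: the limit of > 64000 nM in this assay, at which 2 of the 4 values shown sit. The compounds shown leave open whether hydrogen in place of chloro on this core shifts the read-out at all.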